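The compounds below may be only part of what the source reports. "The series", "measured", "known", "first", "only" and "open" are said of these compounds alone.

The measured compounds:
compound 1 `COc1cccc(N2C(=O)COc3ccc(-c4cnc(OC)c(NS(=O)(=O)c5ccc(F)cc5)c4)cc32)c1` — 11200 nM
compound 2 `O=C1COc2ccc(-c3cccc(NS(=O)(=O)c4ccc(F)cc4)c3)cc2N1c1ccccc1` — > 40000 nM

In a functional assay on A549 cells (Homo sapiens) for antiproliferative activity, read by MTT assay, with a stated time of 72 h (on this read-out lower numbers stand for stronger inhibition and higher numbers for weaker inhibition), compound 1 gives 11200 nM. For compound 2 only a limit of the assay is reported, namely > 40000 nM. Compound 2 therefore stands at the limit of > 40000 nM in this assay, at which 1 of the 2 values shown sits, the weaker end of the two values shown. Going by the values given here, no pair of measured compounds differs in a single place, so no measured step is available from which to judge the size of a change. Compound 3 `O=C1COc2ccc(-c3cccc(NS(=O)(=O)c4ccc(F)cc4)c3)cc2N1c1ccc(F)cc1` has not yet been measured. It differs from compound 2 by fluoro in place of hydrogen on an aromatic carbon. The step is expected to be small, a number no higher from compound 2 to compound 3 (the limit leaves the size open), within the scatter and in no particular direction, and a limit rather than a number is quite possible for compound 3 as well. Compound 3 is expected at 40000 nM, in the range 15000 nM to 100000 nM.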

Compound 3, half-maximal inhibitory concentration: > 40000 nM
Compound 3 was reported as a limit (the forecaster's own chance of this, stated with the estimate: 65%); the middle value sits exactly at the limit.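

Going by these compounds alone, compound 2 and compound 3 are both reported only as limits, so no step from one to the other can be read. The compounds shown leave open whether fluoro in place of hydrogen on an aromatic carbon changes antiproliferative activity at all.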